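A few compounds are considered here, and "the series" means these few. Any claim that something is new, unique, unknown or untested is made for them only; others in the source may bear on it.

Measured compounds: compound 1 `COCn1c(CC(COCc2ccccc2)COCc2ccccc2)cc(=O)[nH]c1=O`, compound 2 `COCn1c(CC(COCc2ccccc2)COCc2ccccc2)c(C)c(=O)[nH]c1=O` and compound 3 `O=c1cc(CC(O)COCc2ccccc2)[nH]c(=O)[nH]1`.

In a functional assay on MIA PaCa-2 cells (Homo sapiens) for antiproliferative activity, read by MTT assay, with a stated time of 72 h (on this read-out lower numbers stand for stronger inhibition and higher numbers for weaker inhibition), compound 1 reaches only the limit > 100000 nM. Compound 2 gives 55900 nM in this assay. Compound 3 likewise sits at the limit > 100000 nM in this assay. The step of an at least 1.7-fold lower number from compound 1 to compound 2 (0.25 log units; that floor lies within the scatter) is the change (methyl in place of hydrogen on an aromatic carbon); it is read against (the limit of > 100000 nM in this assay, at which 2 of the 3 values shown sit). Compound 4 `Cc1c(CC(O)COCc2ccccc2)[nH]c(=O)[nH]c1=O` is not yet measured. It arises from compound 3 by the same kind of change, (methyl in place of hydrogen on an aromatic carbon); here the place is not meta to a methoxymethyl group (3 heavy atoms), as it is in compound 2. How the core of compound 3 differs from that of compound 1 is not broken down here. Within the data shown here, on the single earlier step, compound 4 is expected to move by about an at least 1.4-fold lower number from compound 3 to compound 4 (0.15 log units; that floor lies within the scatter) in this assay, with a real chance that only a limit is seen again. Compound 4 is thus estimated at 70000 nM, between 25000 nM and 200000 nM.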

Compound 4, half-maximal inhibitory concentration: > 100000 nM
Compound 4 ended at the assay's limit; the forecaster's own chance of this, stated with the estimate: 45%; middle value at least 1.4-fold (0.15 log units) away from the limit.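

Among these compounds, compound 3 and compound 4 both end at a limit of the assay, so no step between them can be read: the limit of > 100000 nM in this assay, at which 3 of the 4 values shown sit.

The compounds shown leave open whether the methyl of compound 4 changes activity at all in this assay.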